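From 4-fluorophenyl to 4-cyanophenyl: working notes

A few compounds are considered here, and "the series" means these few. Any claim that something is new, unique, unknown or untested is made for them only; others in the source may bear on it.

Values in a toxicity assay on MT4 cells (Homo sapiens) for cytotoxicity, read by MTT assay (on this read-out higher numbers stand for lower toxicity in this test and lower numbers for higher toxicity in this test), so far
compound 1 `COc1cc(-c2ccc(C#N)cc2)ccc1Oc1cc(N)nc(Nc2ccc(C#N)cc2)n1` gives 120000 nM
compound 2 `Cc1cc(-c2ccccc2F)ccc1Oc1cc(N)nc(Nc2ccc(C#N)cc2)n1` gives 29500 nM
compound 3 `Cc1cc(-c2ccc(F)cc2)ccc1Oc1cc(N)nc(Nc2ccc(C#N)cc2)n1` gives 20100 nM

Compound 3 lies within the scatter of compound 2 and well under compound 1, so it belongs to the low end of this small set in this assay. Compound 4 `Cc1cc(-c2ccc(C#N)cc2)ccc1Oc1cc(N)nc(Nc2ccc(C#N)cc2)n1` has cyano in place of fluoro on an aromatic carbon, para to a large group (cyano in place of fluoro on an aromatic carbon). Going by the values given here, the one measured single-place step, 4-fluorophenyl in place of 2-fluorophenyl, is small (a 1.5-fold lower number from compound 2 to compound 3 (0.17 log units; within the scatter)) and does not exchange fluoro for cyano. Compound 1 (120000 nM) also carries the 4-cyanophenyl group, though it differs from compound 4 elsewhere, and it supports only a weak expectation of an upward move. The expected change is small and no larger than the scatter (a 1.5-fold higher number from compound 3 to compound 4 (0.17 log units; within the scatter)). For compound 4 the estimated value is 30000 nM, with an expected range from 10000 nM to 90000 nM.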

Compound 4, half-maximal cytotoxic concentration: 10400 nM
Estimate against measurement, compound 4: 2.9-fold (0.46 log units) above, and the stated range covers the measured number.
By their numbers in this assay, from the lowest: compounds 4, 3 and 2 (each within the scatter of the next, the first and the last beyond it); then compound 1.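

In this assay, cyano in place of fluoro on this aromatic carbon gives a 1.9-fold lower number from compound 3 to compound 4 (0.29 log units; within the scatter), so exchanging these two groups at this position does not move the number beyond the scatter. With the 4-cyanophenyl group held constant, methyl in place of methoxy gives a 12-fold lower number from compound 1 to compound 4 (1.06 log units; beyond the scatter), so the high number of compound 1 does not come with the 4-cyanophenyl group alone, while moving from the 2-fluorophenyl group to the 4-cyanophenyl group gives a 2.8-fold lower number from compound 2 to compound 4 (0.45 log units; beyond the scatter), a modest step that does reach beyond the scatter. No measurement at hand accounts for any of these steps.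

The compounds shown leave open whether methoxy in place of methyl produces a step of similar size alongside a fluorophenyl group. They also leave open how an amine or a carboxylic acid in place of the cyano on this aromatic carbon would read in this assay.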